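This account rests on a few compounds, and the source may have more. Where it says the series, first, only, none or still open, it means among the compounds named here.

Measured compounds in this set:
- compound 1 `COc1ccc(-c2nn3ccc(NC(C)C)cc3c2-c2ccnc(NC3CCCC3)n2)cc1`: > 40000 nM
- compound 2 `CC(C)COc1ccc(-c2nn3ccc(NC4CCCC4)cc3c2-c2ccnc(NC3CCCC3)n2)cc1`: 27000 nM
- compound 3 `Fc1ccc(-c2nn3c(NC4CC4)cc(Cl)cc3c2-c2ccnc(NC3CCCC3)n2)cc1`: > 40000 nM

In an ADME assay on Vero cells (Chlorocebus sabaeus) for cytotoxicity (on this read-out higher numbers stand for lower toxicity in this test and lower numbers for higher toxicity in this test), compound 3 gives > 40000 nM, which is a limit of the assay and not a number. Compound 1 likewise gives > 40000 nM in this assay, also a limit. For the measured compounds named here, compound 2 gives 27000 nM, the one numerical value in the set. Compound 3 therefore stands with the majority of the set, as noted in the limit of > 40000 nM in this assay, at which 2 of the 3 values shown sit.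

The next compound, compound 4 `Fc1ccc(-c2nn3c(N4CCCCC4)cc(Cl)cc3c2-c2ccnc(NC3CCCC3)n2)cc1`, differs from compound 3 in one place: piperidin-1-yl in place of cyclopropylamino on an aromatic carbon. Going by the values given here, no step between measured compounds is recorded, so the effect of this change has no precedent here. The read-out of this assay already sits at the limit for compound 3, and a step of no size beyond the usual scatter is expected; the step of an at least 1.1-fold lower number from compound 3 to compound 4 (0.05 log units; that floor lies within the scatter) is the expected one. Compound 4 is accordingly estimated at 35000 nM, with a range from 15000 nM to 80000 nM in this assay, and a fair chance that only a limit is reported again.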

Compound 4, half-maximal cytotoxic concentration: > 40000 nM
Compound 4 gave a limit, no number; the forecaster's own chance of this, stated with the estimate: 50%; middle value at least 1.1-fold (0.05 log units) from the limit.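

For the compounds shown here, compound 3 and compound 4 both stand at a limit, so no step between them can be read. In this assay compound 4 gives > 40000 nM as a limit of the assay and not a number. The compounds shown leave open whether piperidin-1-yl and cyclopropylamino differ at all in this assay because most values share one limit: the limit of > 40000 nM in this assay, at which 3 of the 4 values shown sit.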